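Swapping Sulfamoyl for Cyano in an Antiproliferative Series

The source may report more compounds than this note shows. Statements on the series, on what has been measured and on what is new or still open speak of the compounds shown alone.

In a functional assay on SK-OV-3 cells (Homo sapiens) for antiproliferative activity, read by sulforhodamine B assay, with a stated time of 72 h (on this read-out higher numbers stand for weaker inhibition and lower numbers for stronger inhibition), compound 1 `Fc1ccc(Nc2nncc3ccccc23)cc1` gives 0.06 nM and compound 2 `NS(=O)(=O)c1ccc(Nc2nncc3ccccc23)cc1` gives 0.8 nM as the higher of the two numbers. Compound 3 `N#Cc1ccc(Nc2nncc3ccccc23)cc1` is still unmeasured and carries cyano in place of sulfamoyl on an aromatic carbon. Within the data shown here, the one measured step that bears on this is a 13-fold higher number from compound 1 to compound 2 (1.12 log units; beyond the scatter) where sulfamoyl took the place of fluoro. Part of that large step may be won back once sulfamoyl leaves, so a moderate fall in this assay is expected, with a 3.2-fold lower number from compound 2 to compound 3 (0.51 log units; beyond the scatter) as the estimated step. Compound 3 is expected at 0.25 nM within an estimated range of 0.05 nM to 1.2 nM for now.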

Compound 3, half-maximal inhibitory concentration: 0.02 nM
Compound 3: the middle estimate sits 13-fold (1.10 log units) above what was measured, outside the stated range (below it).
By their numbers in this assay, from the lowest: compound 3; then compound 1; then compound 2.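

Within this assay, cyano in place of sulfamoyl gives a 40-fold lower number from compound 2 to compound 3 (1.60 log units; beyond the scatter), and cyano in place of fluoro gives a 3.0-fold lower number from compound 1 to compound 3 (0.48 log units; beyond the scatter). The change therefore does more than win back what sulfamoyl lost: among these three compounds, the group at this position can take the number below that of the fluoro compound as well as above it. No measurement is available to explain these differences. The compounds shown leave open how an amine, a carboxylic acid or a longer chain would fare at this position.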